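Ring swaps at a limit, and an ethynyl step

This account rests on a few compounds, and the source may have more. Where it says the series, first, only, none or still open, it means among the compounds named here.

Compound 1 `Cc1nc(N)c2c(-c3ccoc3)cn([C@@H]3O[C@H](CO)[C@@H](O)[C@H]3O)c2n1`: > 100000 nM (limit)
Compound 2 `Cc1nc(N)c2c(-c3ccsc3)cn([C@@H]3O[C@H](CO)[C@@H](O)[C@H]3O)c2n1`: > 100000 nM (limit)
Compound 3 `Cc1nc(N)c2c(-c3ccccc3)cn([C@@H]3O[C@H](CO)[C@@H](O)[C@H]3O)c2n1`: > 100000 nM (limit)

In an ADME assay on BJ cells (Homo sapiens), read by MTT assay, with a stated time of 72 h (a higher number here means a weaker inhibitor, a lower number a stronger inhibitor), compound 3 stands only at a limit, and no number is available for it. The whole measured set sits the same way, with the limit of > 100000 nM in this assay, at which 3 of the 3 values shown sit.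

Compound 4 `C#Cc1cn([C@@H]2O[C@H](CO)[C@@H](O)[C@H]2O)c2nc(C)nc(N)c12` carries ethynyl in place of phenyl on an aromatic carbon of the shared core: ethynyl in place of phenyl on an aromatic carbon.

The nearest measured steps exchange one ring for another at this place: a step that the two limits leave unreadable from compound 1 to compound 2, a step that the two limits leave unreadable from compound 1 to compound 3 and a step that the two limits leave unreadable from compound 2 to compound 3. For the measured compounds named here, none of them has a readable size, and no measured compound carries a group without a ring there. The expectation therefore rests on compound 3, whose limit is > 100000 nM, and no step beyond the scatter is expected. The estimated step is a number no higher from compound 3 to compound 4 (the limit leaves the size open). For compound 4 the expected value is 100000 nM, with an estimated range of 25000 nM to 120000 nM.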

Compound 4, half-maximal inhibitory concentration: > 100000 nM
Compound 4: only a limit was reported; the forecaster's own chance of this, stated with the estimate: 70%; the middle value sits exactly at the limit.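

The steps from compound 1, compound 2 and compound 3 to compound 4 cannot be read, because all four compounds stand at a limit and not at a number: the limit of > 100000 nM in this assay, at which 4 of the 4 values shown sit.

The compounds shown leave open whether any group at this place on the shared core gives a readable value in this assay.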